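Indole amide at the aryl position of a bis-indole core

The source may report more compounds than this note shows. Statements on the series, on what has been measured and on what is new or still open speak of the compounds shown alone.

Measured in a functional assay on BGC-823 cells (Homo sapiens) for cytotoxicity, read by MTT assay, with a stated time of 72 h; a higher number here means a weaker inhibitor, a lower number a stronger inhibitor:
- compound 1, `CCc1ccc(C(=O)NC[C@H]2c3[nH]c4ccccc4c3C[C@H]3[C@H]4c5[nH]c6ccccc6c5C[C@@H]([C@H](C#N)N23)N4C)cc1`, gives 660 nM
- compound 2, `CN1[C@@H]2c3[nH]c4ccccc4c3C[C@H]1[C@H](C#N)N1[C@@H](CNC(=O)c3cccc4c3CCCC4)c3[nH]c4ccccc4c3C[C@@H]21`, gives 3540 nM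
- compound 3, `CN1[C@@H]2c3[nH]c4ccccc4c3C[C@H]1[C@H](C#N)N1[C@@H](CNC(=O)c3cc4ccccc4s3)c3[nH]c4ccccc4c3C[C@@H]21`, gives 240 nM

Compound 1 stands second highest of the three numbers, with compound 3 nearest and compound 2 furthest. Compound 4, `CN1[C@@H]2c3[nH]c4ccccc4c3C[C@H]1[C@H](C#N)N1[C@@H](CNC(=O)c3cc4ccccc4[nH]3)c3[nH]c4ccccc4c3C[C@@H]21`, has not been measured; it differs from compound 1 by 1H-indol-2-yl in place of 4-ethylphenyl on a carbonyl carbon. Two steps from compound 1 bear on this change: a 5.4-fold higher number from compound 1 to compound 2 (0.73 log units; beyond the scatter), and a 2.8-fold lower number from compound 1 to compound 3 (0.44 log units; beyond the scatter). The entering group, a bicyclic aromatic bearing one hydrogen-bond donor, resembles the 1-benzothiophen-2-yl of compound 3 more than the tetrahydronaphthalenyl of compound 2, so a modest lowering in this assay is expected, as a 2.2-fold lower number from compound 1 to compound 4 (0.34 log units; beyond the scatter). Compound 4 is therefore estimated at 300 nM, between 120 nM and 800 nM.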

Compound 4, half-maximal inhibitory concentration: 1690 nM
The estimate for compound 4 lay 5.6-fold (0.75 log units) below the measured number; the whole stated range lies below it.
By their numbers in this assay, from the lowest: compound 3; then compound 1; then compound 4; then compound 2.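

In this assay, changing only the hetero atom of the five-membered ring on the carbonyl carbon gives a 7.0-fold higher number from compound 3 to compound 4 (0.85 log units; beyond the scatter) and so separates 1H-indol-2-yl clearly from 1-benzothiophen-2-yl. The indole also lies between the earlier groups, with a 2.6-fold higher number from compound 1 to compound 4 (0.41 log units; beyond the scatter) and a 2.1-fold lower number from compound 2 to compound 4 (0.32 log units; beyond the scatter) in this series, so only compound 3 among the bicyclic amides improves on the 4-ethylphenyl of compound 1. No measurement shown here explains these differences. As far as these compounds go, it remains open how a 1-benzofuran-2-yl group, or an indole carrying a methyl on its ring nitrogen, would compare at this place.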